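Swapping one aryl group on compound 3

This account rests on a few compounds, and the source may have more. Where it says the series, first, only, none or still open, it means among the compounds named here.

In an ADME assay on HepG2 cells (Homo sapiens) for cytotoxicity, read by luminescence, CellTiter-Glo and ATP content, with a stated time of 72 h (a higher number here means that more compound is needed for the effect, a lower number that less compound is needed), compound 3 (`COc1cccc(CNCCCNc2ccnc3cc(Oc4cccc(N(C)C)c4)ccc23)c1O`) gives 7300 nM and so stands within the scatter of compound 2 (`COc1ccc(Oc2ccc3c(NCCCNCc4cccc(OC)c4O)ccnc3c2)cc1`) at 5500 nM but higher than compound 1 (`CC(C)(C)c1ccc(Oc2ccc3c(NCCCNCc4ccco4)ccnc3c2)cc1`) at 3100 nM on this scale. In compound 4 (`COc1cccc(CNCCCNc2ccnc3cc(Oc4ccc(C(C)(C)C)cc4)ccc23)c1O`) a single group changes: 4-(tert-butyl)phenyl takes the place of 3-(dimethylamino)phenyl on an oxygen on an aromatic ring (4-(tert-butyl)phenyl in place of 3-(dimethylamino)phenyl on an oxygen on an aromatic ring). Among the compounds with values here, the only measured swap at that place is a 1.3-fold higher number from compound 2 to compound 3 (0.12 log units; within the scatter) and it is a small one. Compound 1 also carries 4-(tert-butyl)phenyl but differs elsewhere, so it offers only a loose guide, hinting at a slightly lower number. No step beyond the scatter is therefore expected in this assay and the estimated step is a 1.5-fold lower number from compound 3 to compound 4 (0.18 log units; within the scatter) in all. Compound 4 is expected at 4800 nM with an estimated range from 2200 nM to 10000 nM as the likely span.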

Compound 4, half-maximal effective concentration: 1500 nM
For compound 4 the middle estimate is 3.2-fold (0.51 log units) above the measured one, outside the stated range (below it).
By their numbers in this assay, from the lowest: compound 4; then compounds 1, 2 and 3 (each within the scatter of the next, the first and the last beyond it).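

In this assay the aryl group on this oxygen can move the number beyond the scatter, which the earlier swap did not do: 4-(tert-butyl)phenyl gives (a 4.9-fold lower number from compound 3 to compound 4 (0.69 log units; beyond the scatter)). Tert-butyl in place of methoxy on an aromatic carbon gives a similar picture (a 3.7-fold lower number from compound 2 to compound 4 (0.56 log units; beyond the scatter)). A second place also counts, as 2-hydroxy-3-methoxyphenyl in place of furan-2-yl gives (a 2.1-fold lower number from compound 1 to compound 4 (0.32 log units; beyond the scatter)).

Nothing available explains why these numbers shift. As far as these compounds go, whether a trifluoromethyl or a carboxylic acid in place of tert-butyl would shift the number further remains open.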